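Swapping Hydroxy for Bromo on a Weakly Cytotoxic Core

The source may report more compounds than this note shows. Statements on the series, on what has been measured and on what is new or still open speak of the compounds shown alone.

Of the compounds shown here, three sharing one core have been tested in a functional assay on DLD-1 cells (Homo sapiens) for cytotoxicity, with a stated time of 48 h; on this read-out higher numbers stand for weaker inhibition and lower numbers for stronger inhibition. Compound 1 `Cc1ccc2c(=O)cc(/C=C/[S+](C)[O-])oc2c1` gives 7000 nM. Compound 2 `C[S+]([O-])/C=C/c1cc(=O)c2cc(O)ccc2o1` reaches only a limit of the assay, > 10000 nM, so no number is known for it. Compound 3 `COc1cccc2oc(/C=C/[S+](C)[O-])cc(=O)c12` likewise stops at a limit, > 10000 nM. Compound 2 therefore stands where two of the three values sit, at the limit of > 10000 nM in this assay, at which 2 of the 3 values shown sit. Compound 4 `C[S+]([O-])/C=C/c1cc(=O)c2cc(Br)ccc2o1` differs from compound 2 in one place: bromo in place of hydroxy on an aromatic carbon. Among the compounds with values here, no step between measured compounds of this kind is known, so the effect of the change cannot be read from data. The step of an at least 1.1-fold lower number from compound 2 to compound 4 (0.04 log units; that floor lies within the scatter) is expected to stay small, within the usual scatter. Compound 4 is estimated at 9000 nM, with a range from 2500 nM to 30000 nM.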

Compound 4, half-maximal inhibitory concentration: 4500 nM
Compound 4: the middle estimate sits 2.0-fold (0.30 log units) above what was measured; the range from low to high includes it.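

In this assay, bromo in place of hydroxy on this aromatic carbon gives an at least 2.2-fold lower number from compound 2 to compound 4 (0.34 log units; beyond the scatter), the first sign that the read-out responds to a change at this position. The true step may be larger, because compound 2 has no number, only a limit of the assay: the limit of > 10000 nM in this assay, at which 2 of the 4 values shown sit.

Within the data shown here, only two groups can be compared at this position, so it stays open whether the change in the read-out comes from adding bromo or from removing hydroxy. From the compounds shown here alone, how chloro, an amine or a carboxylic acid would fare here also remains unknown.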